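Swapping an aryl for a triazolylmethyl on compound 2

The source may hold more compounds than are shown below. What is called first, only, known or untested is meant among the compounds shown, and "the series" means these compounds.

Measured compounds:
- compound 1 `CCC(CC)N(CCN(C)C(=O)CCC(=O)O)Cc1cccc(C(=O)Nc2sc3c(c2C(=O)c2cnn(-c4ccc(Cl)cc4)c2)CCN(S(C)(=O)=O)C3)c1`: 2490 nM
- compound 2 `CCC(CC)N(CCN(C)C(=O)CCC(=O)O)Cc1cccc(C(=O)Nc2sc3c(c2C(=O)c2cnn(-c4ccc(Cl)cc4)c2)CCC(C)(C)C3)c1`: 36 nM

Both compounds were tested in an assay on isolated protein for inhibition of sodium-dependent phosphate transport protein 2B (Homo sapiens); on this read-out higher numbers stand for weaker inhibition and lower numbers for stronger inhibition. Compound 1 gives 2490 nM, and compound 2 gives 36 nM. Of the two, compound 2 has the lower number; the gap between them lies well beyond the scatter of repeated measurements, so compound 2 is the stronger inhibitor of the pair. The two compounds differ in more than one place, so no single change can be credited for this gap.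

Compound 3 `CCC(CC)N(CCN(C)C(=O)CCC(=O)O)Cc1cccc(C(=O)Nc2sc3c(c2C(=O)c2cnn(Cc4nnc[nH]4)c2)CCC(C)(C)C3)c1` has not yet been measured. It is derived from compound 2 by one change: (4H-1,2,4-triazol-3-yl)methyl in place of 4-chlorophenyl on an aromatic nitrogen. Among the measured compounds shown here, no step of this kind has been measured, so the expectation for compound 3 rests only on the value of compound 2 and on the size of the exchange. A group of one kind is replaced by a group of different size and composition on the same ring nitrogen, and such exchanges often shift potency noticeably. Compound 3 is therefore expected to show a weaker result, with the step of an 8.3-fold higher number from compound 2 to compound 3 (0.92 log units; beyond the scatter) as the estimate. Compound 3 is estimated at 300 nM, within a range from 60 nM to 2000 nM.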

Compound 3, half-maximal inhibitory concentration: > 1000 nM
Compound 3 gave a limit, no number; the forecaster's own chance of this, stated with the estimate: 5%; middle value at least 3.3-fold (0.52 log units) away from the limit.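

In this assay, exchanging 4-chlorophenyl for (4H-1,2,4-triazol-3-yl)methyl on an aromatic nitrogen gives an at least 27-fold higher number from compound 2 to compound 3 (1.44 log units; beyond the scatter). Among the compounds shown here, this is the first step that changes one place only, so it shows what compound 1 and compound 2 could not: the group on this nitrogen by itself can decide whether inhibition holds up. Compound 3 stands at a limit of the assay and not at a number, so the step is only a minimum because of that limit: the limit of > 1000 nM in this assay, at which 1 of the 3 values shown sits.

The two groups are close in heavy-atom count, but this single exchange replaces a carbon-only ring bearing chlorine with a nitrogen-rich ring on a methylene link, so the compounds shown leave open which of these features accounts for the loss. Unsubstituted phenyl, 4-chlorobenzyl or a 1,2,4-triazole ring set directly on the nitrogen would separate the role of the chlorine, the methylene link and the ring itself, and a simple methyl would show what this position gives with no ring at all.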